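Lengthening the chain on the ring nitrogen of compound 2

This account rests on a few compounds, and the source may have more. Where it says the series, first, only, none or still open, it means among the compounds named here.

Compound 2 `Clc1ccc(OCc2nc3ccccc3n2CCN2CCCCC2)cc1` carries a 2-(piperidin-1-yl)ethyl chain on an aromatic nitrogen of the shared core. In an assay on isolated protein for binding affinity to Neuropeptide Y receptor type 1 (Homo sapiens) (a higher number here means a weaker inhibitor, a lower number a stronger inhibitor), compound 2 gives only a limit, > 100000 nM, and not a number. It stands at the limit of > 100000 nM in this assay, at which 1 of the 3 values shown sits. Compound 4 `Clc1ccc(OCc2nc3ccccc3n2CCCN2CCCCC2)cc1` differs from it in one place: (piperidin-1-yl)methyl in place of piperidin-1-yl on a saturated chain carbon, two bonds along the chain from an aromatic nitrogen. Of the measured compounds, compound 1 `Oc1cccc2c1nc(COc1ccc(Cl)cc1)n2CCCC1CCCNC1` gives 5300 nM in this assay, and compound 3 `Clc1ccc(OCc2nc3c(OCCC4CCCNC4)cccc3n2CCCC2CCCNC2)cc1` gives 18 nM. Among the measured compounds shown here, the one measured step, a 290-fold lower number from compound 1 to compound 3 (2.47 log units; beyond the scatter), concerns an addition on an oxygen elsewhere on the core, not the chain on the aromatic nitrogen, so it does not bear on the step from compound 2 to compound 4. For the measured compounds named here, compound 1 and compound 2 differ in more than one place, so their two values show only that compound 1 has a number where compound 2 has a limit. Going by the values given here, no measured step speaks to adding one carbon to this chain. The estimate for compound 4 is therefore 60000 nM, with a range from 10000 nM to 300000 nM; the expected step of an at least 1.6-fold lower number from compound 2 to compound 4 (0.22 log units; that floor lies within the scatter) is small, and a limit rather than a number is expected to be about as likely as not.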

Compound 4, inhibition constant: 7020 nM
For compound 4 the middle estimate is 8.5-fold (0.93 log units) above the measured one; the measured number lies below the stated range.
By their numbers in this assay, from the lowest: compound 3; then compounds 1 and 4 (each within the scatter of the next). At a limit, above all of these: compound 2.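

In this assay, the change to (piperidin-1-yl)methyl in place of piperidin-1-yl, on a saturated chain carbon two bonds along the chain from an aromatic nitrogen, gives an at least 14-fold lower number from compound 2 to compound 4 (1.15 log units; beyond the scatter). Among the compounds shown here, this is the first reading of how the chain on the aromatic nitrogen responds to its length, and the answer is that a small change there can be a large one in this assay, whereas the earlier step concerned an addition on an oxygen elsewhere on the core. The size of the step is only a floor, since compound 2 has a limit and not a number: the limit of > 100000 nM in this assay, at which 1 of the 4 values shown sits.

The compounds shown leave open whether a still longer chain, such as 4-(piperidin-1-yl)butyl, would lower the number further or raise it again, since a single step gives no trend along the chain. Also open, on these data alone, is how much depends on the piperidine ring itself, which an open-chain amine such as diethylamino, or a morpholine ring, in its place on the same chain would test.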